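Adding a Methoxy Group: From Compound 1 to Compound 3

The source may hold more compounds than are shown below. What is called first, only, known or untested is meant among the compounds shown, and "the series" means these compounds.

Measured compounds:
compound 1, `COc1c(/C=C2/C(=O)Nc3ccccc32)c2ccccc2n1-c1ccccc1` — 4070 nM
compound 2, `COc1ccc2c(c1)/C(=C\c1c(Cl)n(C/C=C/c3ccccc3)c3ccccc13)C(=O)N2` — 30200 nM

In a functional assay on cells (Cancer cell lines, Homo sapiens) for cytotoxicity, with a stated time of 48 h (on this read-out lower numbers stand for stronger inhibition of growth and higher numbers for weaker inhibition of growth), compound 1 gives 4070 nM, the lower of the two numbers measured. Compound 2 gives 30200 nM in this assay, a higher number, and the gap to compound 1 lies beyond the scatter. The two compounds differ in several places at once, so their pair says nothing about any single change.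

Compound 3, `COc1ccc2c(c1)/C(=C\c1c(OC)n(-c3ccccc3)c3ccccc13)C(=O)N2`, differs from compound 1 by one change: methoxy in place of hydrogen on an aromatic carbon. Going by the values given here, no pair of measured compounds shows this change on its own, so there is no measured step to lean on. The expectation is that such a small addition leaves the number close to that of compound 1, with the step of a 1.2-fold lower number from compound 1 to compound 3 (0.07 log units; within the scatter) expected to stay within the scatter. For compound 3 the estimate in this assay is 3500 nM, with a range from 1200 nM to 10000 nM.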

Compound 3, concentration for total growth inhibition: 17400 nM
Estimate against measurement, compound 3: 5.0-fold (0.70 log units) below; the measured number lies above the stated range.
By their numbers in this assay, from the lowest: compound 1; then compounds 3 and 2 (each within the scatter of the next).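

In this assay, going by these compounds alone, methoxy in place of hydrogen on an aromatic carbon gives a 4.3-fold higher number from compound 1 to compound 3 (0.63 log units; beyond the scatter) and is the first single change that can be read here. The earlier compounds shown here differ in several places at once and could not show what this position does on its own. This carbon of the six-membered aromatic ring, meta to a fused ring and para to a fused ring, is therefore not indifferent to substitution, and the added methoxy weakens growth inhibition beyond the scatter; no measurement at hand accounts for this shift.

Only methoxy is shown at this carbon, and it remains open whether the loss follows from any addition there or from methoxy alone. On these data alone, how a fluorine atom, an amine or a carboxylic acid would read at the same place also remains open.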